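The compounds below may be only part of what the source reports. "The series", "measured", "known", "first", "only" and "open" are said of these compounds alone.

Compound 1, `Nc1ccc2cccc(OC3CCCCC3)c2n1`, gives 361 nM in an assay on cells with melanin-concentrating hormone receptor 1 (Homo sapiens) as the target, read by radioligand binding; on this read-out lower numbers stand for stronger inhibition and higher numbers for weaker inhibition. Compound 2, `CC#CCCOc1cccc2ccc(N)nc12`, reaches only the limit > 2000 nM in this assay. Compound 3, `CC1CC1COc1cccc2ccc(N)nc12`, gives 1640 nM in this assay.

Of the two numbers, compound 3 stands highest, above compound 1 by the step of a 4.5-fold higher number from compound 1 to compound 3 (0.66 log units; beyond the scatter). Compound 4, `Nc1ccc2cccc(OC3CCCC3)c2n1`, differs from compound 3 by cyclopentyl in place of (2-methylcyclopropyl)methyl on an oxygen on an aromatic ring. Within the data shown here, two measured steps bear on it: a 4.5-fold higher number from compound 1 to compound 3 (0.66 log units; beyond the scatter) and an at least 5.5-fold higher number from compound 1 to compound 2 (0.74 log units; beyond the scatter), both worsening when cyclohexyl is replaced; the latter is only bounded, since compound 2 sits at the limit of > 2000 nM in this assay, at which 1 of the 3 values shown sits. Cyclopentyl is a ring like cyclohexyl, so a lower number is expected, the step of a 3.3-fold lower number from compound 3 to compound 4 (0.52 log units; beyond the scatter). Compound 4 is therefore estimated at 500 nM, between 200 nM and 1500 nM.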

Compound 4, half-maximal inhibitory concentration: > 2000 nM
Compound 4 gave a limit, no number; the forecaster's own chance of this, stated with the estimate: 10%; middle value at least 4.0-fold (0.60 log units) from the limit.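

Among the groups on this oxygen, ring size alone already matters: cyclopentyl in place of cyclohexyl raises the number as much as the open-chain group did (an at least 5.5-fold higher number from compound 1 to compound 4 (0.74 log units; beyond the scatter)), so compound 1 alone keeps the lowest number. The floor of the other step (an at least 1.2-fold higher number from compound 3 to compound 4 (0.08 log units; that floor lies within the scatter)) sets no order between those two compounds, and the step between compound 2 and compound 4 cannot be read. Compound 4 gives a limit, not a number, as compound 2 does: the limit of > 2000 nM in this assay, at which 2 of the 4 values shown sit.

Open, from the compounds shown here alone, is whether cycloheptyl would hold or lower the number seen with cyclohexyl. Also open, going by these compounds, is how an amine on the cyclohexyl ring would fare.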